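Swapping dimethylamino for tert-butyl in compound 2

A few compounds are considered here, and "the series" means these few. Any claim that something is new, unique, unknown or untested is made for them only; others in the source may bear on it.

Measured in a functional assay on A2780 cells (Homo sapiens) for inhibition, read by sulforhodamine B assay, with a stated time of 72 h; on this read-out higher numbers stand for weaker inhibition and lower numbers for stronger inhibition:
- compound 1 `CCNC1=C(C)C(=O)C=C(C(C)C)C1=O`: 12600 nM
- compound 2 `CC1=CC(=O)C(N(C)C)=CC1=O`: 6200 nM
- compound 3 `CC1=C(N(C)C)C(=O)C=CC1=O`: 16700 nM

Compound 2 has the lowest number of the three, so it is the strongest inhibitor in this small set, and the gaps to compound 1 and compound 3 both lie beyond the usual scatter. The next compound, compound 4 `CC1=CC(=O)C(C(C)(C)C)=CC1=O`, keeps the core of compound 2 and changes one group: tert-butyl in place of dimethylamino on a double-bonded ring carbon. For the measured compounds named here, no pair of measured compounds isolates this change, so the data offer no direct guide to it. All three values do lie close together, though, with even compound 3 at 16700 nM. No step beyond the scatter is therefore expected in this assay, only a slight drift towards weaker inhibition, and the estimated step is a 1.3-fold higher number from compound 2 to compound 4 (0.11 log units; within the scatter). The expected value for compound 4 is 8000 nM, with an estimated range of 2500 nM to 25000 nM.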

Compound 4, half-maximal inhibitory concentration: 7500 nM
For compound 4 the middle estimate is 1.1-fold (0.03 log units) above the measured one; low and high end bracket the measured number.
By their numbers in this assay, from the lowest: compounds 2, 4, 1 and 3 (each within the scatter of the next, the first and the last beyond it).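

In this assay, for the compounds shown here, putting tert-butyl in place of dimethylamino on this double-bonded ring carbon gives a 1.2-fold higher number from compound 2 to compound 4 (0.08 log units; within the scatter), the first comparison in this set in which only one place changes. At this position, then, a group holding nitrogen and one hydrogen-bond acceptor gives way to an all-carbon group with no acceptor, and the step stays within the scatter of repeated measurements. Nothing at hand explains why these two groups read alike.

Going by these compounds, it remains open whether other groups at this ring carbon, such as a primary amine, a carboxylic acid or a longer alkyl chain, would also stay within the scatter of compound 2. Also open, on these data alone, is whether the same swap would read alike with an ethyl group in place of the methyl group on the ring.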